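The source may hold more compounds than are shown below. What is called first, only, known or untested is meant among the compounds shown, and "the series" means these compounds.

Compound 1 `CNC(=O)[C@@]12C[C@@H]1[C@@H](n1cnc3c(NC)nc(C#Cc4ccc(-c5ccccc5)cc4)nc31)[C@H](O)[C@@H]2O` is tested in an assay on CHO cells for displacement of a labelled ligand from adenosine receptor A1 (Homo sapiens), read by scintillation counting, with a stated time of 60 min, tested at 10 uM (a higher number here means more inhibition at the concentration tested (going by the name of the read-out), a lower number less inhibition), where compound 1 gives 18%. Among the compounds with values here, the only other measured compound is compound 2 `CNC(=O)[C@@]12C[C@@H]1[C@@H](n1cnc3c(NC)nc(C#Cc4ccccc4OC)nc31)[C@H](O)[C@@H]2O`, which in this assay gives 12%; the change between them, a number 6 percentage points lower from compound 1 to compound 2 (within the scatter), leaves the two values within the scatter of each other, and both show little inhibition at the concentration tested. Compound 3 `CNC(=O)[C@@]12C[C@@H]1[C@@H](n1cnc3c(NC)nc(C#Cc4ncccn4)nc31)[C@H](O)[C@@H]2O` has not yet been measured. Compared with compound 1 it differs in one place: pyrimidin-2-yl in place of 4-phenylphenyl on a triple-bonded carbon. Within the data shown here, the one measured step that bears on this, a number 6 percentage points lower from compound 1 to compound 2 (within the scatter), also replaced the 4-phenylphenyl group on the triple-bonded carbon with a smaller aromatic ring, and it stayed within the scatter. On that evidence no step beyond the scatter is expected in this assay in either direction, and the estimate for compound 3 is 12%, with a range from 0% to 28%. That corresponds to an expected a number 6 percentage points lower from compound 1 to compound 3 (within the scatter).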

Compound 3, a percentage reported as inhibition, at one concentration (the size of the read-out at that concentration, not a potency): 25%
Estimate against measurement, compound 3: 13 percentage points below; the range from low to high includes it.
By their numbers in this assay, from the lowest: compounds 2, 1 and 3 (each within the scatter of the next, the first and the last beyond it).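

Within the data shown here, the triple-bonded carbon now carries a ring with hetero atoms for the first time, and in this assay pyrimidin-2-yl in place of 4-phenylphenyl gives a number 7 percentage points higher from compound 1 to compound 3 (within the scatter), so this group of two carbon-only rings can give way to a single ring containing nitrogen without a step beyond the scatter. Pyrimidin-2-yl in place of 2-methoxyphenyl gives a number 13 percentage points higher from compound 2 to compound 3 (beyond the scatter), the only step here that clears the scatter, and it is a modest one, so the choice of ring at this position can shift the read-out a little, though inhibition stays low in all three compounds. Nothing available explains this difference.

The compounds shown leave open whether a pyridin-2-yl ring would fall with the carbon-only rings or with pyrimidin-2-yl in this assay. Also open, on these data alone, is how a group without an aromatic ring, such as an aminomethyl group or a carboxylic acid, would behave on the triple-bonded carbon.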